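A few compounds are considered here, and "the series" means these few. Any claim that something is new, unique, unknown or untested is made for them only; others in the source may bear on it.

Among the measured compounds shown here, in a functional assay for binding affinity, with Homo sapiens as the target, read by fluorescence and flow cytometry (a higher number here means weaker binding, a lower number tighter binding), compound 2 (`O=C(O)CCNC(=O)c1cc2sc(CCC3CCNCC3)cc2s1`) gives about 600 nM and stands highest of the two numbers so far, whereas compound 1 (`O=C(NC[C@H](NS(=O)(=O)c1ccccc1)C(=O)O)c1cc2sc(CCC3CCNCC3)cc2s1`) gives 0.15 nM in the same read-out. Compound 3 (`O=C(NCc1ccccc1)N[C@@H](CNC(=O)c1cc2sc(CCC3CCNCC3)cc2s1)C(=O)O`) departs from compound 2 by (benzylcarbamoyl)amino in place of hydrogen on a saturated chain carbon bound to a carbonyl carbon and a saturated chain carbon and so fills again the place that holds (phenylsulfonyl)amino in compound 1. For the measured compounds named here, the one measured step bearing on this, a 4000-fold higher number from compound 1 to compound 2 (3.60 log units; beyond the scatter) (large, beyond the scatter), removes that group. A different group enters here, so a large but not necessarily full return is expected, an estimated 600-fold lower number from compound 2 to compound 3 (2.78 log units; beyond the scatter) towards tighter binding. Compound 3 is estimated at 1 nM with 0.15 nM to 8 nM as the expected range.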

Compound 3, dissociation constant: 33 nM
Estimate against measurement, compound 3: 33-fold (1.52 log units) below; the measured number lies above the stated range.
By their numbers in this assay, from the lowest: compound 1; then compound 3; then compound 2.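

Putting (benzylcarbamoyl)amino on the saturated chain carbon gives an 18-fold lower number from compound 2 to compound 3 (1.26 log units; beyond the scatter) and so recovers only part of what was lost, while benzylcarbamoyl in place of phenylsulfonyl on the amine nitrogen leaves a 220-fold higher number from compound 1 to compound 3 (2.34 log units; beyond the scatter) as the remaining gap. This position therefore does not merely need filling: the group on that amine nitrogen strongly shapes the read-out. Nothing measured here accounts for the gap between these two groups. As far as these compounds go, whether the free amine, an acetyl or a benzylsulfonyl on that nitrogen would stand nearer compound 1 or compound 2 remains open.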